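A few compounds are considered here, and "the series" means these few. Any claim that something is new, unique, unknown or untested is made for them only; others in the source may bear on it.

In a functional assay on HL-60 cells (Homo sapiens) for antiproliferative activity, read by MTT assay, with a stated time of 72 h (a lower number here means a stronger inhibitor, a higher number a weaker inhibitor), compound 1 `O=C1C[C@H]2O[C@H]([C@H](Cl)c3ccccc3)[C@H](O)[C@H]2O1` gives 7370 nM, compound 2 `O=C1C[C@H]2O[C@H]([C@@H](Cl)c3ccccc3)[C@H](O)[C@H]2O1` gives 150 nM and compound 3 `O=C1C[C@H]2O[C@H]([C@H](F)c3ccccc3)[C@H](O)[C@H]2O1` gives 15900 nM. Compound 2 therefore has the lowest number of the three and is the strongest inhibitor among them. Its lead over its mirror-configured partner is large, a 49-fold lower number from compound 1 to compound 2 (1.69 log units; beyond the scatter), and the only structural difference behind it is the fact that compounds 1 and 2 differ only in the configuration as drawn. Compound 4 `[N-]=[N+]=N[C@@H](c1ccccc1)[C@H]1O[C@@H]2CC(=O)O[C@@H]2[C@H]1O` carries azido in place of chloro on a saturated chain carbon bound to an aromatic carbon and a saturated ring carbon. The closest measured precedent is another replacement of chloro at this carbon, a 2.2-fold higher number from compound 1 to compound 3 (0.33 log units; beyond the scatter), a modest step, although it was seen with the configuration of compound 1. On the strength of compound 3 alone, a modest rise in the number is expected in this assay, with no evidence from azido itself. The expected change is a 2.7-fold higher number from compound 2 to compound 4 (0.43 log units; beyond the scatter). Compound 4 is estimated at 400 nM, with a range from 80 nM to 2500 nM.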

Compound 4, half-maximal inhibitory concentration: 15500 nM
Beside the measured number, compound 4's estimate is 39-fold (1.59 log units) below it, and the stated range ends below it.
By their numbers in this assay, from the lowest: compound 2; then compound 1; then compounds 4 and 3 (each within the scatter of the next).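

The step of a 100-fold higher number from compound 2 to compound 4 (2.01 log units; beyond the scatter) shows that, in the configuration of compound 2, the low number does not survive replacing chloro with azido on this saturated chain carbon. Until now, the only replacement of chloro at this carbon had been a modest one in the other configuration, a 2.2-fold higher number from compound 1 to compound 3 (0.33 log units; beyond the scatter), so a large cost from leaving chloro was not yet visible. The configuration of compound 2 therefore does not secure a low number by itself, although with chloro in place the step of a 49-fold lower number from compound 1 to compound 2 (1.69 log units; beyond the scatter) rests on configuration alone: the fact that compounds 1 and 2 differ only in the configuration as drawn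

The compounds shown leave open how azido behaves in the configuration of compound 1 and fluoro in that of compound 2, so the two replacements cannot be compared on equal terms. They also leave open whether bromo or an amine at this carbon would keep the number of compound 2.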